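Aryl replacement at the shared core: expected acid dissociation

This account rests on a few compounds, and the source may have more. Where it says the series, first, only, none or still open, it means among the compounds named here.

Measured compounds:
compound 1 `COc1ccc(F)cc1CNCCCNc1ccnc2cc(Cc3ccc(F)cc3Cl)ccc12` — 9.47
compound 2 `Fc1ccc(Cc2ccc3c(NCCCNCc4ccco4)ccnc3c2)c(Cl)c1` — 9.47
compound 3 `c1ccc(-c2ccc3c(NCCCNCc4ccco4)ccnc3c2)cc1` — 9.47

In a physicochemical assay for acid dissociation, compound 1 gives 9.47, level with compound 2 and compound 3 at the digits shown. The step of no change at the digits printed from compound 1 to compound 2 (within the scatter) and the step of no change at the digits printed from compound 2 to compound 3 (within the scatter) both stay within the scatter, so across these three the read-out is flat.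

Compound 4 `COc1ccc(F)cc1CNCCCNc1ccnc2cc(-c3ccc(C(C)(C)C)cc3)ccc12` is the next member. Its difference from compound 1 is 4-(tert-butyl)phenyl in place of 2-chloro-4-fluorobenzyl on an aromatic carbon. The group exchange sits on the aromatic carbon of the shared core, away from the chain amine.

The step from compound 2 to compound 3 is the one that bears on this change: there too a group on the same aromatic carbon was exchanged, and no change at the digits printed from compound 2 to compound 3 (within the scatter) shows nothing beyond the scatter. The exchange of the chain-end aryl between compound 1 and compound 2, no change at the digits printed from compound 1 to compound 2 (within the scatter), was also flat. Among the measured compounds shown here, on these three compounds alone, no step in this assay beyond the scatter is expected for compound 4, in either direction.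

The value for compound 4 in this assay is therefore estimated at 9.47, with a range from 9.17 to 9.77. The expected step of no change at the digits printed from compound 1 to compound 4 (within the scatter) is within the scatter.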

Compound 4, acid dissociation constant: 9.47
Beside the measured number, compound 4's estimate shows no gap at the digits printed; the measured number falls inside the stated range.
By their numbers in this assay, from the lowest: compounds 1, 2, 3 and 4 (each within the scatter of the next).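

In this assay the exchange of 2-chloro-4-fluorobenzyl for 4-(tert-butyl)phenyl on this aromatic carbon gives no change at the digits printed from compound 1 to compound 4 (within the scatter) and so adds a second flat exchange at this position. The earlier exchange here, no change at the digits printed from compound 2 to compound 3 (within the scatter), was read only with furan-2-yl at the chain end and with an unsubstituted phenyl entering. The new step extends that reading to a series member carrying 5-fluoro-2-methoxyphenyl at the chain end and to an entering phenyl with a tert-butyl group, so at this position neither the benzyl-to-phenyl exchange nor the added tert-butyl group moves the read-out beyond the scatter in these compounds. No supporting measurement is available to explain why the read-out stays level at this position.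

As far as these compounds go, it remains open whether the read-out would also stay level with a carboxylic acid or a dimethylamino group on the entering phenyl, or with a pyridine ring in its place. Also open, from the compounds shown here alone, is how it would respond to a change at the chain itself, such as a longer chain or an amide in place of the chain amine.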